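A few compounds are considered here, and "the series" means these few. Any claim that something is new, unique, unknown or untested is made for them only; others in the source may bear on it.

Compound 1 `CC(C)N(Cc1cccc(OCCCCCC(=O)O)c1)C(=O)c1ccc(-c2cccc(OCc3ccccc3)c2)cc1` gives, in an ADME assay on Raji cells (Homo sapiens) for cytotoxicity, read by CellTiter-Glo and resazurin assay, with a stated time of 72 h (on this read-out higher numbers stand for an effect only at larger amounts of compound and lower numbers for an effect already at smaller amounts), a limit of > 26000 nM. Compound 2 `CCOC(=O)CCCCCOc1cccc(CN(C(=O)c2ccc(-c3ccc(C(C)=O)s3)cc2)C(C)C)c1` gives in this assay a limit of > 26000 nM. Compound 3 `CCOC(=O)CCCCCOc1cccc(CN(C(=O)c2ccc(-c3cccc(OCc4ccccc4)c3)cc2)C(C)C)c1` gives in this assay a limit of > 26000 nM.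

Compound 3 thus stands only at a limit, not at a number. All three values shown sit at the limit of > 26000 nM in this assay, at which 3 of the 3 values shown sit. Among the compounds with values here, the single measured step between compounds differing in one place, a step that the two limits leave unreadable from compound 1 to compound 3, is left unreadable by its two limits.

Compound 4 `CCOC(=O)CCCCCOc1cccc(CN(C(=O)c2ccc(-c3cccc(C(F)(F)F)c3)cc2)C(C)C)c1` differs from compound 3 in one place: trifluoromethyl in place of benzyloxy on an aromatic carbon. Within the data shown here, no measured step bears on this change, and the one step available carries no size, so no direction can be read from the data. Compound 4 is expected to show no effect within the tested range, with the step that the limit leaves unreadable from compound 3 to compound 4 estimated as none beyond the scatter. Compound 4 is estimated at 30000 nM, between 15000 nM and 80000 nM.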

Compound 4, half-maximal effective concentration: > 26000 nM
Compound 4 gave a limit, no number (the forecaster's own chance of this, stated with the estimate: 80%); the middle value is on the limit's open side.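

In this assay compound 4 gives only a limit, and compound 2 and compound 3 also stand at limits, so the steps to compound 4 cannot be read: the limit of > 26000 nM in this assay, at which 4 of the 4 values shown sit. The compounds shown leave open which change, if any, would bring a measurable effect in this assay.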